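Demethylating a phenyl ether on a pyrimidine hydrazone

The compounds below may be only part of what the source reports. "The series", "measured", "known", "first", "only" and "open" are said of these compounds alone.

Measured compounds in a functional assay on HCT-116 cells (Homo sapiens) for antiproliferative activity, read by MTT assay; on this read-out lower numbers stand for stronger inhibition and higher numbers for weaker inhibition:
compound 1 `COc1cccc(/C=N/Nc2ncc3c(n2)n(C2CCCC2)c(=O)c(=O)n3C)c1` gives 45800 nM
compound 2 `Cn1c(=O)c(=O)n(C2CCCC2)c2nc(N/N=C/c3cc(C(F)(F)F)c(O)c(C(F)(F)F)c3)ncc21` gives 27100 nM
compound 3 `Cn1c(=O)c(=O)n(C2CCCC2)c2nc(N/N=C/c3cc(C(F)(F)F)cc(C(F)(F)F)c3)ncc21` gives 4360 nM

Compound 1 stands at the highest of the three numbers; its value sits within the scatter of compound 2, but well beyond that of compound 3. Compound 4 `Cn1c(=O)c(=O)n(C2CCCC2)c2nc(N/N=C/c3cccc(O)c3)ncc21` differs from compound 1 by hydrogen in place of methyl on an oxygen on an aromatic ring. Among the measured compounds shown here, no measured step matches this change. The nearest hint is a 6.2-fold lower number from compound 2 to compound 3 (0.79 log units; beyond the scatter), where removing a hydroxy group from the aromatic ring lowered the number; a hydroxy group entering here might therefore move the number upward, though that step involved a different substitution pattern. A small change in this assay, upward if anything, is expected; the expected step is a 1.3-fold higher number from compound 1 to compound 4 (0.12 log units; within the scatter). Compound 4 is estimated at 60000 nM, within 20000 nM to 180000 nM.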

Compound 4, half-maximal inhibitory concentration: 37200 nM
The estimate for compound 4 lay 1.6-fold (0.21 log units) above the measured number; the range from low to high includes it.
By their numbers in this assay, from the lowest: compound 3; then compounds 2, 4 and 1 (each within the scatter of the next).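

In this assay, going from 3-methoxyphenyl to 3-hydroxyphenyl gives a 1.2-fold lower number from compound 1 to compound 4 (0.09 log units; within the scatter), so the two compounds cannot be told apart. Among the compounds shown here, on this ring, then, the methyl on the oxygen can be exchanged for hydrogen with no change that the assay can resolve, a type of change that no earlier step covered. No available evidence gives a reason for this result. Still open, on these data alone, is whether an amine or a carboxylic acid in this place, or a longer chain on the oxygen such as ethoxy, would move the number beyond the scatter.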